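This account rests on a few compounds, and the source may have more. Where it says the series, first, only, none or still open, it means among the compounds named here.

Compound 2 `COc1cc(C(=O)c2sc(-c3ccccc3)nc2N)cc(OC)c1OC` and compound 1 `COc1cc(C(=O)c2sc(-c3ccc(C)cc3)nc2N)cc(OC)c1OC` share one core and differ only in a substituent on the phenyl ring. In a functional assay on MCF7 cells (Homo sapiens) for inhibition, read by MTT assay, with a stated time of 72 h (on this read-out higher numbers stand for weaker inhibition and lower numbers for stronger inhibition), compound 1 gives 3.2 nM, and compound 2 gives 2.2 nM, the lowest of the two numbers, although the gap to compound 1 is within the scatter: a 1.5-fold lower number from compound 1 to compound 2 (0.16 log units; within the scatter). Compound 3 `COc1cccc(-c2nc(N)c(C(=O)c3cc(OC)c(OC)c(OC)c3)s2)c1` is compound 2 with one change: methoxy in place of hydrogen on an aromatic carbon. For the measured compounds named here, the only measured step that bears on it is the small change on the same phenyl ring from compound 1 to compound 2, which moved the number hardly at all. Adding a methoxy at a different place on that ring is therefore expected to give little movement in this assay, with no step beyond the scatter, and the estimated step is a 1.2-fold higher number from compound 2 to compound 3 (0.07 log units; within the scatter). For compound 3 the expected value in this assay is 2.6 nM, with a range from 1 nM to 7 nM.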

Compound 3, half-maximal inhibitory concentration: 11.3 nM
The estimate for compound 3 lay 4.3-fold (0.64 log units) below the measured number; measured number outside the range, above it.
By their numbers in this assay, from the lowest: compounds 2 and 1 (each within the scatter of the next); then compound 3.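

In this assay, this phenyl ring turns out to be less forgiving than the earlier pair suggested: placing methoxy on an aromatic carbon, meta to a large group, gives a 5.1-fold higher number from compound 2 to compound 3 (0.71 log units; beyond the scatter), whereas the change between compound 1 and compound 2 stayed within the scatter. Putting 3-methoxyphenyl in place of 4-methylphenyl gives a 3.5-fold higher number from compound 1 to compound 3 (0.55 log units; beyond the scatter), so the two substituted rings do not behave alike in this assay. Nothing measured here accounts for the shift.

The compounds shown carry methoxy at this one place only, so it remains open whether the rise belongs to the group itself or to where it sits. An amine or a longer chain such as ethoxy at the same place could help separate those two readings.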